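The compounds below may be only part of what the source reports. "The series", "measured", "known", "first", "only" and "open" are said of these compounds alone.

The compounds share one core and differ only in the groups fixed on it. Compound 1, `CN(C)c1nc(N)c2ncn([C@@H]3C[C@@H](O)[C@H](CO)O3)c2n1`, gives in a functional assay on U-937 cells (Homo sapiens) (a higher number here means a weaker inhibitor, a lower number a stronger inhibitor), a result that is a limit of the assay, > 300 uM. Compound 2, `CSc1nc(SC)c2ncn([C@@H]3C[C@@H](O)[C@H](CO)O3)c2n1`, likewise reaches only the limit of the assay in this assay, > 300 uM. Compound 2 thus stands where every result so far sits, at the limit of > 300 uM in this assay, at which 2 of the 2 values shown sit, and no number sets it apart from compound 1. Compound 3, `CNc1nc(SC)nc2c1ncn2[C@@H]1C[C@@H](O)[C@H](CO)O1`, is not yet measured in this assay. It differs from compound 2 by methylamino in place of methylsulfanyl on an aromatic carbon. Among the compounds with values here, no measured step shows what such a change does here, and the two limits give no direction. The step of a number no higher from compound 2 to compound 3 (the limit leaves the size open) is expected to stay within the scatter. For compound 3 the estimate is 300 uM, within 60 uM to 1000 uM.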

Compound 3, concentration for 50% inhibition: > 300 uM
Compound 3: a limit, no number; the forecaster's own chance of this, stated with the estimate: 75%; the middle value sits exactly at the limit.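

Compound 3 gives > 300 uM in this assay, a limit of the assay and not a number. Within the data shown here, compound 2 also gives only a limit, so no step from compound 2 to compound 3 can be read. The compounds shown leave open whether any change of group on the shared core alters inhibition at all: the limit of > 300 uM in this assay, at which 3 of the 3 values shown sit.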